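The source may hold more compounds than are shown below. What is called first, only, known or untested is meant among the compounds shown, and "the series" means these compounds.

In a functional assay on NCI-H460 cells (Homo sapiens) for cytotoxicity, read by MTT assay, with a stated time of 72 h (on this read-out lower numbers stand for stronger inhibition and higher numbers for weaker inhibition), three compounds share one core and differ in the ring on a double-bonded chain carbon bound to an aromatic carbon. Compound 1 (`CC(C)c1[nH]cnc1/C=c1\[nH]c(=O)/c(=C/c2cccc(Oc3ccc(F)cc3)c2)[nH]c1=O`) gives 8.8 nM in this read-out, and compound 2 (`O=c1[nH]/c(=C\c2ccccn2)c(=O)[nH]/c1=C\c1cccc(Oc2ccc(F)cc2)c1`) gives 49.1 nM there. Compound 3 (`O=c1[nH]/c(=C\c2cccs2)c(=O)[nH]/c1=C\c1cccc(Oc2ccc(F)cc2)c1`) is recorded only as a limit (> 1000 nM). Compound 4 (`O=c1[nH]/c(=C\c2ccc([N+](=O)[O-])o2)c(=O)[nH]/c1=C\c1cccc(Oc2ccc(F)cc2)c1`) changes that same place: 5-nitrofuran-2-yl in place of thiophen-2-yl on a double-bonded chain carbon bound to an aromatic carbon in the structure. Ring exchanges there have moved the number considerably: a 5.6-fold higher number from compound 1 to compound 2 (0.75 log units; beyond the scatter) was modest, while an at least 110-fold higher number from compound 1 to compound 3 (2.05 log units; beyond the scatter) and an at least 20-fold higher number from compound 2 to compound 3 (1.30 log units; beyond the scatter) were large. A lower number is therefore expected, a modest to large drop, estimated as an at least 3.3-fold lower number from compound 3 to compound 4 (0.52 log units; beyond the scatter) with wide uncertainty. The estimate for compound 4 is 300 nM within an expected range of 40 nM to 2000 nM in this assay.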

Compound 4, half-maximal inhibitory concentration: > 1000 nM
Compound 4 was reported as a limit; the forecaster's own chance of this, stated with the estimate: 30%; middle value at least 3.3-fold (0.52 log units) away from the limit.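

Compound 4 is recorded in this assay only as a limit, > 1000 nM. With 5-nitrofuran-2-yl, a second ring at this place falls well behind the pyridin-2-yl and 5-isopropyl-1H-imidazol-4-yl compounds, with an at least 20-fold higher number from compound 2 to compound 4 (1.30 log units; beyond the scatter) and an at least 110-fold higher number from compound 1 to compound 4 (2.05 log units; beyond the scatter). The step between compound 3 and compound 4 cannot be read, as both stand only at the limit: the limit of > 1000 nM in this assay, at which 2 of the 4 values shown sit.

From the compounds shown here alone, how far compound 3 and compound 4 lie past that limit stays open. Going by these compounds, it also remains open whether an amine or a carboxylic acid on the pyridin-2-yl ring would keep the number near that of compound 2.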